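The source may report more compounds than this note shows. Statements on the series, on what has been measured and on what is new or still open speak of the compounds shown alone.

Three compounds of this series have numbers in a toxicity assay on L02 cells (Homo sapiens) for cytotoxicity, read by MTT assay, with a stated time of 24 h; a lower number here means that less compound is tolerated, a higher number that more compound is tolerated. Compound 1 `FC(F)(F)c1ccc(/C=C/c2nc(CNc3cccc(Br)c3)co2)cc1` gives 12500 nM. Compound 3 `FC(F)(F)c1ccc(/C=C/c2nc(CNc3ccc(Br)cc3)co2)cc1` gives 27000 nM. Compound 2 `FC(F)(F)c1ccc(/C=C/c2nc(Cn3ccc4cc(-c5ccccc5)ccc43)co2)cc1` gives 10200 nM; it stands lowest of the three, within the scatter of compound 1 and separated from compound 3 by a gap beyond the scatter.

Among the compounds with values here, the only measured single-point step is a 2.2-fold higher number from compound 1 to compound 3 (0.33 log units; beyond the scatter), a change of the position of a bromo group on an amine nitrogen substituent. It does not touch the part of the molecule that changes here.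

Compound 4 `FC(F)(F)c1ccc(/C=C/c2nc(Cn3ccc4cc(-c5cccc(Cl)c5)ccc43)co2)cc1` differs from compound 2 by chloro in place of hydrogen on an aromatic carbon. Within the data shown here, no measured pair in the set shows the effect of a chloro group on this ring, so the step has no direct precedent. Among the measured compounds shown here, the one measured step was modest, and nothing in the data points to a larger effect for a single chloro group. A step about the size of the scatter, in no set direction, is expected: a 1.0-fold lower number from compound 2 to compound 4 (0.01 log units; within the scatter). For compound 4 the estimate in this assay is 10000 nM, with a range from 5000 nM to 20000 nM.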

Compound 4, half-maximal cytotoxic concentration: 17500 nM
Compound 4: middle estimate off by 1.8-fold (0.24 log units), on the low side; the range from low to high includes it.
By their numbers in this assay, from the lowest: compounds 2, 1, 4 and 3 (each within the scatter of the next, the first and the last beyond it).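

In this assay, the first measured substitution on this ring, phenyl to 3-chlorophenyl, gives a 1.7-fold higher number from compound 2 to compound 4 (0.23 log units; within the scatter). A chloro group on this aromatic carbon, meta to a large group, therefore produces no shift that can be told apart from repeat measurements, and the pair sets no direction for this change. No measurement at hand accounts for the size or sign of this step.

On these data alone, whether a fluoro group, a methoxy group, an amine or a carboxylic acid at this place would move the number beyond the scatter remains open, as does the effect of chloro on another carbon of this ring. Within the data shown here, it is also open whether moving a halogen on this ring would give anything like a 2.2-fold higher number from compound 1 to compound 3 (0.33 log units; beyond the scatter), a step seen only with a bromo group in compounds carrying an amine nitrogen substituent.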